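A bromo for methyl at the limit of the assay

A few compounds are considered here, and "the series" means these few. Any claim that something is new, unique, unknown or untested is made for them only; others in the source may bear on it.

In a functional assay on HL-60 cells (Homo sapiens) for antiproliferative activity, read by sulforhodamine B assay, with a stated time of 72 h (on this read-out higher numbers stand for weaker inhibition and lower numbers for stronger inhibition), compound 1 (`COc1ccccc1NC(=S)N/N=C/c1ccc2ccccc2n1`) gives 91700 nM as a measured number. Compound 2 (`COc1ccc(C)cc1NC(=S)N/N=C/c1ccc2ccccc2n1`) shows > 100000 nM as a limit of the assay. Compound 3 (`Cc1cccc(NC(=S)N/N=C/c2ccc3ccccc3n2)c1`) likewise shows > 100000 nM as a limit, which places it with compound 2 (the limit of > 100000 nM in this assay, at which 2 of the 3 values shown sit). Compound 4 (`S=C(N/N=C/c1ccc2ccccc2n1)Nc1cccc(Br)c1`) carries bromo in place of methyl on an aromatic carbon. The nearest measured steps are (an at least 1.0-fold higher number from compound 1 to compound 3 (0.03 log units; that floor lies within the scatter)) and (an at least 1.0-fold higher number from compound 1 to compound 2 (0.03 log units; that floor lies within the scatter)), both only floors, and neither involves bromo, so no step beyond the scatter is expected in this assay in either direction. The expected step is small (an at least 1.2-fold lower number from compound 3 to compound 4 (0.09 log units; that floor lies within the scatter)). Compound 4 is estimated at 80000 nM with an expected range from 20000 nM to 150000 nM in this read-out.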

Compound 4, half-maximal inhibitory concentration: 53800 nM
Beside the measured number, compound 4's estimate is 1.5-fold (0.17 log units) above it; the measured number falls inside the stated range.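

In this assay compound 4 gives a measured number with bromo at this place, whereas compound 3, with methyl there, is known only as a limit, and that limit remains common among the compounds shown: the limit of > 100000 nM in this assay, at which 2 of the 4 values shown sit. The step is only a floor, an at least 1.8-fold lower number from compound 3 to compound 4 (0.26 log units; that floor lies within the scatter), so it does not give the size of this change. The wider change reads a 1.7-fold lower number from compound 1 to compound 4 (0.23 log units; within the scatter), so 3-bromophenyl and 2-methoxyphenyl on this nitrogen are not told apart here.

On these data alone, whether an amine or a carboxylic acid at this place would move the number beyond the scatter from compound 4 stays open.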